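The source may hold more compounds than are shown below. What is called first, only, known or untested is meant among the compounds shown, and "the series" means these compounds.

Measured in a functional assay on KB-VIN10 cells (Homo sapiens) for inhibition, with a stated time of 72 h; a lower number here means a stronger inhibitor, a higher number a weaker inhibitor:
- compound 1 `COc1ccc(S(=O)(=O)N2CCc3cccc(-c4ccc(N)cc4)c32)cc1`: 262 nM
- compound 2 `COc1ccc(S(=O)(=O)N2CCc3cccc(-c4ccc([N+](=O)[O-])cc4)c32)cc1`: 51.3 nM
- compound 3 `COc1ccc(S(=O)(=O)N2CCc3cccc(-c4ccc(F)c(F)c4)c32)cc1`: 46 nM

Compound 3 carries a 3,4-difluorophenyl group and sits level with compound 2, as the measured step is a 1.1-fold lower number from compound 2 to compound 3 (0.05 log units; within the scatter). Against compound 1 the picture is different, with a 5.7-fold lower number from compound 1 to compound 3 (0.76 log units; beyond the scatter). The matching step for the nitro compound is a 5.1-fold lower number from compound 1 to compound 2 (0.71 log units; beyond the scatter).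

The next structure is compound 4 `COc1ccc(-c2cccc3c2N(S(=O)(=O)c2ccc(OC)cc2)CC3)cc1`. It keeps the shared core and places 4-methoxyphenyl in place of 3,4-difluorophenyl on an aromatic carbon.

Among the measured compounds shown here, no measured step brings in the 4-methoxyphenyl group, so the evidence is indirect. Of the three measured groups, only the 4-aminophenyl of compound 1 stands apart, while the other two give values within the scatter of each other. With so few compounds, this is a weak guide. A step beyond the scatter is therefore not expected in this assay, and no direction is favoured with any confidence. Compound 1, at 262 nM, shows that a change in this group can move the number by a modest amount, so the range is kept wide.

The expected result is a 1.1-fold higher number from compound 3 to compound 4 (0.04 log units; within the scatter). For compound 4 the estimated value is 50 nM, with an expected range from 15 nM to 170 nM.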

Compound 4, half-maximal inhibitory concentration: 352 nM
Beside the measured number, compound 4's estimate is 7.0-fold (0.85 log units) below it; the measured number lies above the stated range.
By their numbers in this assay, from the lowest: compounds 3 and 2 (each within the scatter of the next); then compounds 1 and 4 (each within the scatter of the next).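

In this assay, the 4-aminophenyl group of compound 1 no longer stands alone at this position, on an aromatic carbon ortho to a fused ring, as 4-methoxyphenyl also separates clearly from 3,4-difluorophenyl, with a 7.7-fold higher number from compound 3 to compound 4 (0.88 log units; beyond the scatter), and from 4-nitrophenyl, with a 6.9-fold higher number from compound 2 to compound 4 (0.84 log units; beyond the scatter). Compound 4 instead sits level with compound 1, with a 1.3-fold higher number from compound 1 to compound 4 (0.13 log units; within the scatter), so the four compounds now form two sets: compounds 2 and 3 together, and compounds 1 and 4 together. The change from 3,4-difluorophenyl to 4-methoxyphenyl keeps 8 heavy atoms and one six-membered aromatic ring of carbon only, so a step of this size at this position does not need a change in either count, and nothing measured here accounts for the split into two sets.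

The compounds shown leave open where a 4-fluorophenyl or a 3,4-dimethoxyphenyl group would fall, and so whether the fluorine atoms, the methoxy group or the number of ring substituents tracks the split. They also leave open whether a 4-hydroxyphenyl or a 4-carboxyphenyl group would join either set.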